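The source may hold more compounds than are shown below. What is called first, only, known or untested is meant among the compounds shown, and "the series" means these compounds.

Compound 1 `COc1cccc(/C=C/C(=O)Nc2cc(C(=O)c3cc(OC)c(OC)c(OC)c3)ccc2OC)c1` gives 3100 nM in a functional assay on B16 cells (Mus musculus) for cytotoxicity, read by MTT assay, with a stated time of 72 h; a higher number here means a weaker inhibitor, a lower number a stronger inhibitor; compound 2 `C#CCOc1cccc(/C=C/C(=O)Nc2cc(C(=O)c3cc(OC)c(OC)c(OC)c3)ccc2OC)c1` gives 12200 nM; compound 3 `COc1ccc(C(=O)c2cc(OC)c(OC)c(OC)c2)cc1NC(=O)/C=C/c1ccc(N)cc1` gives 7900 nM.

Compound 3 holds the second highest of these three numbers. Its nearest neighbour is compound 2, with a step that stays inside the scatter a 1.5-fold lower number from compound 2 to compound 3 (0.19 log units; within the scatter), while compound 1 is furthest away a 2.5-fold higher number from compound 1 to compound 3 (0.41 log units; beyond the scatter).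

Compound 4 `COc1ccc(C(=O)c2cc(OC)c(OC)c(OC)c2)cc1NC(=O)/C=C/c1ccc([N+](=O)[O-])cc1` has not yet been measured. It differs from compound 3 in one place: nitro in place of amino on an aromatic carbon. Within the data shown here, no measured step exchanges these two groups. The two steps that altered the same aryl group were modest, a 2.5-fold higher number from compound 1 to compound 3 (0.41 log units; beyond the scatter) and a 1.5-fold lower number from compound 2 to compound 3 (0.19 log units; within the scatter), and the third step, a 3.9-fold higher number from compound 1 to compound 2 (0.59 log units; beyond the scatter), concerns another part of the shared core. The expected step in this assay is therefore small and of uncertain direction: a 1.2-fold lower number from compound 3 to compound 4 (0.08 log units; within the scatter). Compound 4 is estimated to give about 6500 nM, between 2200 nM and 20000 nM.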

Compound 4, half-maximal inhibitory concentration: 6400 nM
Compound 4: middle estimate off by 1.0-fold (0.01 log units), on the high side, and the stated range covers the measured number.
By their numbers in this assay, from the lowest: compound 1; then compounds 4, 3 and 2 (each within the scatter of the next).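

In this assay, nitro in place of amino on this aromatic carbon, para to a large group, leaves the number in place (a 1.2-fold lower number from compound 3 to compound 4 (0.09 log units; within the scatter)), so the hydrogen-bond donor of amino shows no measurable effect here. The 4-nitrophenyl group also stays level with 3-(propargyloxy)phenyl (a 1.9-fold lower number from compound 2 to compound 4 (0.28 log units; within the scatter)), but 3-methoxyphenyl keeps the lower number (a 2.1-fold higher number from compound 1 to compound 4 (0.31 log units; beyond the scatter)). From the compounds shown here alone, whether a hydroxyl, a methyl or a dimethylamino group on this carbon would also stay level remains open. No evidence is available that could explain these results.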